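Dropping the bromine from the benzyl ring of compound 2

This account rests on a few compounds, and the source may have more. Where it says the series, first, only, none or still open, it means among the compounds named here.

Of the compounds shown here, three of a shared core have been tested in a functional assay on MCF7 cells (Homo sapiens) for cytotoxicity, read by MTT assay, with a stated time of 24 h; on this read-out higher numbers stand for weaker inhibition and lower numbers for stronger inhibition. Compound 1, `O=c1nc2ccc(Br)cn2cc1Cc1ccccc1`, carries a bromine on the core itself; in this assay compound 1 reaches only the limit of > 1000000 nM, which is a boundary of the measurement and not a number. Compound 2, `O=c1nc2ccccn2cc1Cc1ccc(Br)cc1`, moves the bromine onto the benzyl ring, and in this assay compound 2 gives 157000 nM. Compound 3, `O=c1nc2ccc(Cl)cn2cc1Cc1ccc(F)cc1C(F)(F)F`, which carries a chlorine on the core and a fluorine together with a trifluoromethyl on the benzyl ring, gives 181000 nM in this assay; the numbers for compound 2 and compound 3 lie within the usual scatter of each other, so neither can be called the stronger one.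

Compound 4, `O=c1nc2ccccn2cc1Cc1ccccc1`, is the unsubstituted parent of compound 2: hydrogen in place of bromo on an aromatic carbon. Going by the values given here, no measured pair shows this exact change. Since the one limit, (the limit of > 1000000 nM in this assay, at which 1 of the 3 values shown sits), belongs to a compound that differs in another place, the expected step is small, no more than the scatter or a slight weakening. Compound 4 is therefore expected at about 300000 nM, between 100000 nM and 1000000 nM, an expected step of a 1.9-fold higher number from compound 2 to compound 4 (0.28 log units; within the scatter).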

Compound 4, half-maximal inhibitory concentration: 75400 nM
Beside the measured number, compound 4's estimate is 4.0-fold (0.60 log units) above it, and the stated range ends above it.
By their numbers in this assay, from the lowest: compound 4; then compounds 2 and 3 (each within the scatter of the next). At a limit, above all of these: compound 1.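

In this assay, putting hydrogen in place of bromo on the benzyl ring gives a 2.1-fold lower number from compound 2 to compound 4 (0.32 log units; beyond the scatter) and so provides the first readable one-place change: this bromine is not needed for the effect, and the compound without it gives the lower number. The same replacement on the core runs in the same direction, with an at least 13-fold lower number from compound 1 to compound 4 (1.12 log units; beyond the scatter) as its step. Compound 1 stands at a limit, so that step is a bound and not an exact size: the limit of > 1000000 nM in this assay, at which 1 of the 4 values shown sits.

On these data alone, only bromo and hydrogen can be compared at each of these two places, so it remains open how an amine or a carboxylic acid on the benzyl ring would compare with hydrogen. The same question stands for a methoxy group or a longer chain on the core.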